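Removing the trifluoromethylanilino from compound 3

This account rests on a few compounds, and the source may have more. Where it says the series, first, only, none or still open, it means among the compounds named here.

Measured compounds and their values:
compound 1 `COc1cc(-c2nn(-c3cccc(NC(=O)c4ccc(Cl)c(C(F)(F)F)c4)c3)cc2-c2ccncc2)ccc1Cl`: > 32500 nM
compound 2 `O=C(Nc1cccc(-n2cc(-c3ccncc3)c(-c3ccc(Cl)c(O)c3)n2)c1)Nc1cc(C(F)(F)F)cc(C(F)(F)F)c1`: 3310 nM
compound 3 `COc1cc(-c2nn(-c3cccc(NC(=O)Nc4cccc(C(F)(F)F)c4)c3)cc2-c2ccncc2)ccc1Cl`: 24700 nM

In a functional assay on OVCAR-3 cells (Homo sapiens) for inhibition, read by sulforhodamine B assay, with a stated time of 48 h (on this read-out lower numbers stand for higher toxicity in this test and higher numbers for lower toxicity in this test), compound 3 gives 24700 nM, the highest of the two plain numbers, meaning the lowest toxicity; compound 2 gives 3310 nM, a lower number beyond the scatter. For compound 1 the assay reports only a limit, > 32500 nM (the limit of > 32500 nM in this assay, at which 1 of the 3 values shown sits). Among the compounds with values here, the one step measured in one place, an at least 1.3-fold lower number from compound 1 to compound 3 (0.11 log units; that floor lies within the scatter), stays within the scatter.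

Compound 4 `COc1cc(-c2nn(-c3cccc(NC(=O)c4ccccc4)c3)cc2-c2ccncc2)ccc1Cl` has not yet been measured. It differs from compound 3 in one place: phenyl in place of (3-(trifluoromethyl)phenyl)amino on a carbonyl carbon. Within the data shown here, no measured step changes this same group, so the step to compound 4 can only be read loosely. Compound 1 also carries a carbonyl joined to a ring without an amino bridge, and it gives only a limit. The expectation for compound 4 is therefore a number near that of compound 3 or a limit, with the step of a 1.0-fold higher number from compound 3 to compound 4 (0.01 log units; within the scatter) expected to lie within the scatter. Compound 4 is estimated at 25000 nM, between 8000 nM and 70000 nM.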

Compound 4, concentration lethal to 50% of the cells: 95800 nM
Estimate against measurement, compound 4: 3.8-fold (0.58 log units) below, and the stated range ends below it.
By their numbers in this assay, from the lowest: compound 2; then compound 3; then compound 4.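

In this assay, the group on this carbonyl carbon turns out to matter: phenyl in place of (3-(trifluoromethyl)phenyl)amino gives a 3.9-fold higher number from compound 3 to compound 4 (0.59 log units; beyond the scatter). Within the data shown here, the only step readable before this one stayed within the scatter, so this is the first clear sign that a change at this position can shift the number, here towards lower toxicity in this test. The step from compound 1 cannot be read because compound 1 has only a limit: the limit of > 32500 nM in this assay, at which 1 of the 4 values shown sits.

This change removes the amino bridge and the trifluoromethyl together, and the compounds shown do not separate the two. As far as these compounds go, it remains open whether a plain phenylamino group, keeping the bridge but carrying no trifluoromethyl, would give a number closer to that of compound 3 or that of compound 4.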